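Trimethoxyphenyl chromone: effect of capping the phenol

The source may hold more compounds than are shown below. What is called first, only, known or untested is meant among the compounds shown, and "the series" means these compounds.

Measured compounds:
compound 1 `COC(=O)c1c(-c2ccc(OC)cc2)oc2ccccc2c1=O`: > 25 ug/mL
compound 2 `COC(=O)c1c(-c2ccc(O)cc2)oc2ccccc2c1=O`: > 25 ug/mL
compound 3 `COc1cc(-c2cc(=O)c3cc(O)ccc3o2)cc(OC)c1OC`: 5.87 ug/mL

In a functional assay on SK-MEL cells (Homo sapiens) for cytotoxicity, read by MTT assay, with a stated time of 6 days (a lower number here means that less compound is needed, a higher number that more compound is needed for the effect), compound 1 reaches only the limit of > 25 ug/mL, not a number. Compound 2 likewise gives only the limit of > 25 ug/mL in this assay. Among the measured compounds shown here, compound 3 gives 5.87 ug/mL in this assay, the only real number among the three. The change from compound 2 to compound 1, (methyl in place of hydrogen on an oxygen on an aromatic ring), made a step that the two limits leave unreadable from compound 2 to compound 1. The difference between the core of compound 3 and that of compound 2 is not broken down here.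

Compound 4 `COc1ccc2oc(-c3cc(OC)c(OC)c(OC)c3)cc(=O)c2c1` carries the same change, (methyl in place of hydrogen on an oxygen on an aromatic ring), on the core of compound 3. Since the step from compound 2 to compound 1 sits at the limit (the limit of > 25 ug/mL in this assay, at which 2 of the 3 values shown sit), it gives no size to lean on. The step from compound 3 to compound 4 is therefore expected to be small, a 1.5-fold higher number from compound 3 to compound 4 (0.19 log units; within the scatter). Compound 4 is estimated to give 9 ug/mL in this assay, with a plausible range from 3 ug/mL to 25 ug/mL.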

Compound 4, concentration for half-maximal effect: > 25 ug/mL
Compound 4: a limit, no number; the forecaster's own chance of this, stated with the estimate: 25%; at least 2.7-fold (0.44 log units) between middle value and limit.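

In this assay compound 4 gives only a limit, > 25 ug/mL, not a number. On the core of compound 3, hydroxy to methoxy therefore makes an at least 4.2-fold higher number from compound 3 to compound 4 (0.62 log units; beyond the scatter), a step beyond the scatter whose true size may be larger still. This does not show that the change carries the same size from one core to another, as the step from compound 2 to compound 1 cannot be read and offers nothing to set against it: the limit of > 25 ug/mL in this assay, at which 3 of the 4 values shown sit.

The compounds shown leave open how far the number for compound 4 lies past its limit. They also leave open how an amine, a carboxylic acid or an ethoxy group in place of the hydroxy of compound 3 would read in this assay.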